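This account rests on a few compounds, and the source may have more. Where it says the series, first, only, none or still open, it means among the compounds named here.

Three compounds share one core, seen in compound 1 `Cc1ccc(C(=O)Nc2ccc(CNC(=O)OCc3cccnc3)cc2)c(N2CCCC2)c1`, compound 2 `Cc1ccc(N2CCCC2)c(C(=O)Nc2ccc(CNC(=O)OCc3cccnc3)cc2)c1` and compound 3 `O=C(NCc1ccc(NC(=O)c2cc(Br)ccc2N2CCCC2)cc1)OCc1cccnc1`. In a functional assay on AGS cells (Homo sapiens) for inhibition, read by MTT assay, with a stated time of 72 h (a higher number here means a weaker inhibitor, a lower number a stronger inhibitor), compound 1 reaches only a limit of the assay, > 100000 nM. Compound 2 gives 24700 nM in this assay. Compound 3 likewise sits at a limit of the assay, > 100000 nM. For the measured compounds named here, the single measured step in the group, an at least 4.0-fold higher number from compound 2 to compound 3 (0.60 log units; beyond the scatter), has a limit as its second value, as the limit of > 100000 nM in this assay, at which 2 of the 3 values shown sit, notes, so only its floor is known. Compound 4 `O=C(NCc1ccc(NC(=O)c2cc(C(F)(F)F)ccc2N2CCCC2)cc1)OCc1cccnc1` differs from compound 3 by trifluoromethyl in place of bromo on an aromatic carbon. Going by the values given here, no measured step concerns a trifluoromethyl group, so the expectation rests on where compound 3 already stands. In the step from methyl to bromo the number rose beyond what this assay reports, and the numbers give no ground to expect that a trifluoromethyl group in place of bromo brings it back toward compound 2. Compound 4 is therefore expected to remain near the limit, with an estimated 100000 nM and a range of 30000 nM to 300000 nM. The step this estimate implies, a number no higher from compound 3 to compound 4 (the limit leaves the size open), is expected to lie within the scatter.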

Compound 4, half-maximal inhibitory concentration: > 100000 nM
Compound 4 gave a limit, no number (the forecaster's own chance of this, stated with the estimate: 65%); the middle value sits exactly at the limit.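

At this aromatic carbon, para to a pyrrolidin-1-yl group, trifluoromethyl in place of methyl gives an at least 4.0-fold higher number from compound 2 to compound 4 (0.60 log units; beyond the scatter), so the rise in the number seen with bromo is now also seen with a second group. Among the compounds with a group at this carbon, only compound 2, with methyl, gives a number and not a limit, 24700 nM. Compound 3 and compound 4 both sit at a limit, so the step between them cannot be read and bromo and trifluoromethyl cannot be put in order: the limit of > 100000 nM in this assay, at which 3 of the 4 values shown sit.

The compounds shown leave open whether a methoxy group, a fluoro group or an amine at this carbon would give a readable number. They also leave open whether any group here would give a lower number than methyl does in compound 2.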